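Methyl to methoxy on two cores: one step, one forecast

This account rests on a few compounds, and the source may have more. Where it says the series, first, only, none or still open, it means among the compounds named here.

Compound 1 `Cc1cccc(/C=C2\Cc3ccccc3C2=O)c1` gives 50400 nM in a functional assay on L1210 cells (Mus musculus) for inhibition; on this read-out lower numbers stand for stronger inhibition and higher numbers for weaker inhibition. Compound 2 `COc1cccc(/C=C2\Cc3ccccc3C2=O)c1` carries the change methoxy in place of methyl on an aromatic carbon and gives 217000 nM in this assay, a step of a 4.3-fold higher number from compound 1 to compound 2 (0.63 log units; beyond the scatter). Compound 3 `Cc1cccc(/C=C2\CCCCCC2=O)c1` rests on a different core; the difference between the two cores is not broken down here. In this assay compound 3 gives 263000 nM. Compound 4 `COc1cccc(/C=C2\CCCCCC2=O)c1` is not yet measured and differs from compound 3 by methoxy in place of methyl on an aromatic carbon. This is the same kind of change as that from compound 1 to compound 2; the place is given as "meta to a group of 9 heavy atoms" in one case and "meta to a large group" in the other. Within the data shown here, the expected step is a 3.4-fold higher number from compound 3 to compound 4 (0.53 log units; beyond the scatter), resting on the single precedent a 4.3-fold higher number from compound 1 to compound 2 (0.63 log units; beyond the scatter) and on compound 3 already giving 263000 nM. Compound 4 is therefore estimated at 900000 nM, between 300000 nM and 3000000 nM.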

Compound 4, half-maximal inhibitory concentration: 283000 nM
The estimate for compound 4 lay 3.2-fold (0.50 log units) above the measured number, outside the stated range (below it).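

In this assay, methoxy in place of methyl on an aromatic carbon gives a 1.1-fold higher number from compound 3 to compound 4 (0.03 log units; within the scatter), so the size of the step seen on the core of compound 1 does not carry over to the core of compound 3: the same change on two cores in this assay, a 4.3-fold higher number (0.63 log units; beyond the scatter) from compound 1 to compound 2 and a 1.1-fold higher number (0.03 log units; within the scatter) from compound 3 to compound 4, 4.0-fold (0.60 log units) apart, beyond the scatter of two such steps With one pair on each core, this shows that the step can depend on the core, but not how it would behave on any other core. It also does not show which part of the core difference matters.

Open, from the compounds shown here alone, is whether a third core would follow either pair. Also open, going by these compounds, is whether an amine or a carboxylic acid in place of the methyl would differ between these two cores.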